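The source may report more compounds than this note shows. Statements on the series, on what has been measured and on what is new or still open speak of the compounds shown alone.

Measured so far in a functional assay on Jurkat cells (Homo sapiens) for cytotoxicity, read by colorimetric assay, with a stated time of 72 h; on this read-out lower numbers stand for stronger inhibition and higher numbers for weaker inhibition:
- compound 1 `OC[C@H](NC[C@H]1NC[C@H](O)[C@@H]1O)c1ccc(-c2ccccc2)cc1`: > 200000 nM
- compound 2 `OC[C@H](NC[C@H]1NC[C@H](O)[C@@H]1O)c1ccc(-c2ccc(C(F)(F)F)cc2)cc1` gives 75000 nM as a measured number.

Compound 1, by contrast, has for its figure a limit of this assay and not a number, as shown by the limit of > 200000 nM in this assay, at which 1 of the 2 values shown sits. Compound 1 thus stands at the weak end of the two values, with only a ceiling known for it. The step followed here leads to compound 3 `OC[C@H](NC[C@H]1NC[C@H](O)[C@@H]1O)c1ccc(-c2ccsc2)cc1`, in which (thiophen-3-yl in place of phenyl on an aromatic carbon). Among the measured compounds shown here, the only measured step, an at least 2.6-fold lower number from compound 1 to compound 2 (0.42 log units; beyond the scatter), concerns a different change, so it bears only loosely on the swap to thiophen-3-yl. With nothing closer to draw on, the step of a number no higher from compound 1 to compound 3 (the limit leaves the size open) is expected to stay small, and a limit again seems the most likely outcome. Compound 3 is estimated at 200000 nM, with a range from 60000 nM to 600000 nM.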

Compound 3, half-maximal inhibitory concentration: "not active" (no number reported)
Compound 3 has no reported number here, so the estimate cannot be set against anything.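

Among the compounds shown here, compound 3 is reported only as "not active", with no number, so no step from compound 1 to compound 3 can be read. The compounds shown leave open whether thiophen-3-yl in place of phenyl changes the result at all in this assay.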